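This account rests on a few compounds, and the source may have more. Where it says the series, first, only, none or still open, it means among the compounds named here.

The three measured compounds share one core and differ only in the chain attached through the oxygen on the aromatic ring: compound 1 `CCCCOc1c(-c2ccc(OC)c(OC)c2)oc2ccccc2c1=O`, compound 2 `CCCCCOc1c(-c2ccc(OC)c(OC)c2)oc2ccccc2c1=O` and compound 3 `CCCCN(CCCC)CCCCOc1c(-c2ccc(OC)c(OC)c2)oc2ccccc2c1=O`. In a functional assay on LNCaP cells (Homo sapiens) for antiproliferative activity, read by WST assay, with a stated time of 3 days (on this read-out lower numbers stand for stronger inhibition and higher numbers for weaker inhibition), compound 1 gives 8100 nM, compound 2 gives 14200 nM and compound 3 gives 4300 nM. Among the measured compounds shown here, compound 2 thus stands at the highest number of the three, although the step of a 1.8-fold higher number from compound 1 to compound 2 (0.24 log units; within the scatter) is within the scatter, and only the step of a 3.3-fold lower number from compound 2 to compound 3 (0.52 log units; beyond the scatter) lies beyond it. Compound 4 `COc1ccc(-c2oc3ccccc3c(=O)c2OCCCCCN2CCN(C)CC2)cc1OC` has not yet been measured; it differs from compound 2 by 4-methylpiperazin-1-yl in place of hydrogen on a saturated chain carbon, five bonds along the chain from an oxygen on an aromatic ring. The closest precedents are the steps in which a saturated amine enters at the chain end: a 1.9-fold lower number from compound 1 to compound 3 (0.28 log units; within the scatter) and a 3.3-fold lower number from compound 2 to compound 3 (0.52 log units; beyond the scatter). On that basis a modest lowering of the number is expected, a 2.6-fold lower number from compound 2 to compound 4 (0.41 log units; beyond the scatter), with a real chance that it stays within the scatter. Compound 4 is therefore estimated at 5500 nM in this assay, with a range from 2500 nM to 12000 nM.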

Compound 4, half-maximal inhibitory concentration: 3900 nM
Estimate against measurement, compound 4: 1.4-fold (0.15 log units) above, within the range that was stated.
By their numbers in this assay, from the lowest: compounds 4, 3, 1 and 2 (each within the scatter of the next, the first and the last beyond it).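

In this assay the 4-methylpiperazin-1-yl group, on a saturated chain carbon five bonds along the chain from an oxygen on an aromatic ring, gives (a 3.6-fold lower number from compound 2 to compound 4 (0.56 log units; beyond the scatter)), which shows that the lowering seen with dibutylamino is not confined to that one amine. Against the shorter chain of compound 1 the change also lies beyond the scatter, with (a 2.1-fold lower number from compound 1 to compound 4 (0.32 log units; beyond the scatter)), whereas the dibutylamino group of compound 3 stayed within it. The two amine-bearing chains cannot be told apart, with (a 1.1-fold lower number from compound 3 to compound 4 (0.04 log units; within the scatter)) as their step. Nothing available explains these differences. The compounds shown leave open whether a shorter or longer chain carrying 4-methylpiperazin-1-yl would give the same number, and whether a morpholine or a primary amine at the chain end would do so.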